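Replacing the pyridone in compound 3 with a hydroxycyclohexenyl ring

The source may hold more compounds than are shown below. What is called first, only, known or untested is meant among the compounds shown, and "the series" means these compounds.

Measured compounds:
compound 1, `C[C@@H](O[C@H]1CN2C(=O)C=C(c3cc[n+]([O-])cc3)CC2[C@@H]1c1ccc(F)cc1)c1cc(C(F)(F)F)cc(C(F)(F)F)c1`, 0.1 nM
compound 2, `COc1cc(C2=CC(=O)N3C[C@H](O[C@H](C)c4cc(C(F)(F)F)cc(C(F)(F)F)c4)[C@@H](c4ccc(F)cc4)C3C2)ccn1`, 1.1 nM
compound 3, `C[C@@H](O[C@H]1CN2C(=O)C=C(c3cc[nH]c(=O)c3)CC2[C@@H]1c1ccc(F)cc1)c1cc(C(F)(F)F)cc(C(F)(F)F)c1`, 0.27 nM

In an assay on CHO cells for displacement of a labelled ligand from Substance-P receptor (Homo sapiens) (on this read-out lower numbers stand for stronger inhibition and higher numbers for weaker inhibition), compound 3 stands second highest of the three numbers; its nearest neighbour is compound 1, with a 2.7-fold higher number from compound 1 to compound 3 (0.43 log units; beyond the scatter), and its furthest is compound 2, with a 4.1-fold lower number from compound 2 to compound 3 (0.61 log units; beyond the scatter). Compound 4, `C[C@@H](O[C@H]1CN2C(=O)C=C(C3=CCC(O)CC3)CC2[C@@H]1c1ccc(F)cc1)c1cc(C(F)(F)F)cc(C(F)(F)F)c1`, differs from compound 3 by a group of 7 heavy atoms (6 carbon, 1 oxygen; one six-membered non-aromatic ring of carbon only) in place of a group of 7 heavy atoms (5 carbon, 1 nitrogen, 1 oxygen; one six-membered aromatic ring with 1 hetero atom), on a double-bonded ring carbon. Among the compounds with values here, no measured step swaps an aromatic ring for a non-aromatic one at this position; the steps of an 11-fold higher number from compound 1 to compound 2 (1.04 log units; beyond the scatter) and a 2.7-fold higher number from compound 1 to compound 3 (0.43 log units; beyond the scatter) show only that changing the group on this carbon has moved this assay by modest to large amounts. Compound 4 is therefore expected to give a higher number, a 5.6-fold higher number from compound 3 to compound 4 (0.74 log units; beyond the scatter), with the estimate 1.5 nM and a range from 0.4 nM to 6 nM.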

Compound 4, half-maximal inhibitory concentration: 0.18 nM
For compound 4 the middle estimate is 8.3-fold (0.92 log units) above the measured one; measured number outside the range, below it.
By their numbers in this assay, from the lowest: compounds 1, 4 and 3 (each within the scatter of the next, the first and the last beyond it); then compound 2.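

At this double-bonded ring carbon, an aromatic ring with a hetero atom proves unnecessary in this assay: there is a 1.5-fold lower number from compound 3 to compound 4 (0.18 log units; within the scatter) and a 1.8-fold higher number from compound 1 to compound 4 (0.26 log units; within the scatter), so the 4-hydroxycyclohex-1-en-1-yl group, a non-aromatic ring of carbon only, holds the level of both. The 2-methoxypyridin-4-yl group stays apart, with a 6.1-fold lower number from compound 2 to compound 4 (0.79 log units; beyond the scatter). Nothing shown accounts for this result. Still open, as far as these compounds go, is whether the hydroxyl on the new ring is needed at all, and whether an amine or a carboxylic acid in its place would keep this level.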